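This account rests on a few compounds, and the source may have more. Where it says the series, first, only, none or still open, it means among the compounds named here.

Measured compounds:
compound 1 `COc1ccc(C(=O)/C=C/c2cn(-c3ccccc3)nc2-c2ccsc2)c(OC)c1` gives 2200 nM
compound 2 `O=C(/C=C/c1cn(-c2ccccc2)nc1-c1ccncc1)c1cc[nH]c1` gives 15700 nM
compound 3 `O=C(/C=C/c1cn(-c2ccccc2)nc1-c1ccncc1)c1ccccc1` gives 3100 nM

These three compounds were measured in a functional assay on HCT-116 cells (Homo sapiens) for inhibition, read by sulforhodamine B assay, with a stated time of 72 h; a lower number here means a stronger inhibitor, a higher number a weaker inhibitor. Compound 3 stands second highest of the three numbers; its nearest neighbour is compound 1, whose value lies within the scatter of that of compound 3, while compound 2 sits clearly higher. Among the measured compounds shown here, the one step that is known with certainty is a 5.1-fold lower number from compound 2 to compound 3 (0.70 log units; beyond the scatter), which concerns the group on the carbonyl carbon.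

Compound 4 `COc1ccc(C(=O)/C=C/c2cn(-c3ccccc3)nc2-c2ccncc2)c(OC)c1` differs from compound 3 by the change (2,4-dimethoxyphenyl in place of phenyl on a carbonyl carbon). For the measured compounds named here, no measured pair isolates this particular change. Compound 1 carries the same 2,4-dimethoxyphenyl group on its carbonyl carbon, but it also differs from compound 3 in the heteroaryl group on the shared core, so only the two values themselves can be compared: compound 1 and compound 3 lie within the scatter of one another. The expectation is therefore no step beyond the scatter, with the estimated step from compound 3 to compound 4 being a 1.2-fold lower number from compound 3 to compound 4 (0.09 log units; within the scatter). Compound 4 is expected to give 2500 nM, within a range from 1000 nM to 6500 nM.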

Compound 4, half-maximal inhibitory concentration: 4400 nM
The estimate for compound 4 lay 1.8-fold (0.25 log units) below the measured number; measured number inside the range.
By their numbers in this assay, from the lowest: compounds 1, 3 and 4 (each within the scatter of the next); then compound 2.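

In this assay, the exchange of phenyl for 2,4-dimethoxyphenyl on the carbonyl carbon is now seen on its own and gives a 1.4-fold higher number from compound 3 to compound 4 (0.15 log units; within the scatter), so this change leaves the number within the scatter. With pyridin-4-yl held constant, the step of a 3.6-fold lower number from compound 2 to compound 4 (0.55 log units; beyond the scatter) shows that 2,4-dimethoxyphenyl, like phenyl, stands clearly apart from 1H-pyrrol-3-yl at this position. Among the compounds shown here, with 2,4-dimethoxyphenyl held constant, the other position can also be read alone for the first time: pyridin-4-yl in place of thiophen-3-yl on an aromatic carbon gives a 2.0-fold higher number from compound 1 to compound 4 (0.30 log units; within the scatter), again within the scatter.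

The compounds shown leave open whether an amine or a carboxylic acid on the phenyl group at the carbonyl carbon would move the number beyond the scatter. No measurement available here explains why 1H-pyrrol-3-yl stands apart from the other two groups.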